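This account rests on a few compounds, and the source may have more. Where it says the series, first, only, none or still open, it means among the compounds named here.

Compounds measured so far:
compound 1 `C[C@H](/N=C(\S)Nc1ccccn1)c1cccc2ccccc12` – > 100000 nM in a functional assay on RBL-2H3 cells (Rattus norvegicus) for inhibition; a higher number here means a weaker inhibitor, a lower number a stronger inhibitor
compound 2 `Cc1cccc2sc(N/C(S)=N/[C@H](C)c3cccc4ccccc34)nc12` – > 100000 nM
compound 3 `C[C@@H](/N=C(\S)Nc1nc2ccccc2s1)c1cccc2ccccc12` – 18900 nM

Compound 2 sits at a limit of this assay, not at a number, so its standing is known only as a boundary. Compound 1 likewise sits at a limit. Going by the values given here, compound 3 is the one measured compound with a number; an at least 5.2-fold lower number from compound 2 to compound 3 (0.72 log units; beyond the scatter). Against that limit, the limit of > 100000 nM in this assay, at which 2 of the 3 values shown sit, is the only evidence to weigh.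

Compound 4 `Cc1cccc2sc(N/C(S)=N/[C@@H](C)c3cccc4ccccc34)nc12` is to be measured in this assay. It differs from compound 2 as follows: the two compounds have the same atoms and bonds and differ only in configuration as drawn: 1 of 2 stereo elements differ; a stereocentre at a saturated chain carbon is drawn R in compound 2 and S in compound 4. Among the compounds with values here, no measured step involves a change of configuration alone, so none bears directly on this one; the only measured step is the methyl-to-hydrogen change from compound 2 to compound 3. With compound 2 held only as a limit, the step cannot be anchored, and a number for compound 4 anywhere from a clear improvement to another limit would not be surprising. The expected step is an at least 2.0-fold lower number from compound 2 to compound 4 (0.30 log units; that floor lies within the scatter), with the lower number for compound 4 favoured only loosely. Compound 4 is therefore estimated at 50000 nM, within 10000 nM to 150000 nM.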

Compound 4, half-maximal inhibitory concentration: > 100000 nM
Compound 4 ended at the assay's limit; the forecaster's own chance of this, stated with the estimate: 45%; middle value at least 2.0-fold (0.30 log units) away from the limit.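

Compound 2 and compound 4 differ only in configuration as drawn, and each sits at a limit of this assay, so no step between them can be read: the limit of > 100000 nM in this assay, at which 3 of the 4 values shown sit.

The compounds shown leave open whether a change of configuration alone moves the number at all.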